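Methoxy removal on the pendant phenyl ring: anticipated effect

The source may report more compounds than this note shows. Statements on the series, on what has been measured and on what is new or still open speak of the compounds shown alone.

Measured compounds:
compound 1 `COc1ccc2[nH]c(-c3ccccc3)c(C=C(C#N)C#N)c2c1`, 2200 nM
compound 2 `COc1ccc(-c2[nH]c3ccc(OC)cc3c2/C=C(\C#N)S(=O)(=O)c2ccccc2)cc1`, 851 nM
compound 3 `COc1ccc(-c2[nH]c3ccc(OC)cc3c2C=C(C#N)C#N)cc1`, 385 nM

In a functional assay on MCF7 cells (Homo sapiens) for inhibition, read by sulforhodamine B assay, with a stated time of 48 h (a higher number here means a weaker inhibitor of growth, a lower number a stronger inhibitor of growth), compound 3 gives 385 nM, the lowest number of the three. Compound 1 differs from compound 3 by hydrogen in place of methoxy on an aromatic carbon. Compound 1 gives 2200 nM; that step, a 5.7-fold higher number from compound 3 to compound 1 (0.76 log units; beyond the scatter), lies beyond the scatter. Compound 2 gives 851 nM, and the difference between its core and that of compound 3 is not broken down here.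

Compound 4 `COc1ccc2[nH]c(-c3ccccc3)c(/C=C(\C#N)S(=O)(=O)c3ccccc3)c2c1` is not yet measured. It differs from compound 2 by hydrogen in place of methoxy on an aromatic carbon, the same change, at the same place, as that from compound 3 to compound 1. One prior instance is the whole basis, so the expectation rests on it alone. The starting point is compound 2, which gives 851 nM. For the measured compounds named here, compound 4 is expected to show a step of about a 5.3-fold higher number from compound 2 to compound 4 (0.72 log units; beyond the scatter), modelled on a 5.7-fold higher number from compound 3 to compound 1 (0.76 log units; beyond the scatter), and no other step is available. Compound 4 is therefore estimated at 4500 nM, with a range from 1500 nM to 13000 nM. Going by the values given here, the range is wide because only the one step of a 5.7-fold higher number from compound 3 to compound 1 (0.76 log units; beyond the scatter) underlies it.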

Compound 4, concentration for 50% growth inhibition: 3900 nM
Beside the measured number, compound 4's estimate is 1.2-fold (0.06 log units) above it; the measured number falls inside the stated range.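

Replacing 4-methoxyphenyl with phenyl on the core of compound 2 again gives a weaker growth inhibitor in this assay: a 4.6-fold higher number from compound 2 to compound 4 (0.66 log units; beyond the scatter). The change therefore carries from one core to the other in this series, and the two steps cannot be told apart in size: the same change on two cores in this assay, a 5.7-fold higher number (0.76 log units; beyond the scatter) from compound 3 to compound 1 and a 4.6-fold higher number (0.66 log units; beyond the scatter) from compound 2 to compound 4, 1.2-fold (0.10 log units) apart, within the scatter of two such steps. Two pairs in one cell assay are the whole basis, which shows the carry-over only between these two cores and does not show that the step would hold on a further core, nor what lies behind it.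

Still open, from the compounds shown here alone, is whether a hydroxyl group, a fluorine atom, an amine or a longer chain such as ethoxy at the same place would match methoxy or fall closer to hydrogen. Also open, going by these compounds, is what the second methoxy group, common to all four compounds, contributes to growth inhibition.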